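The source may report more compounds than this note shows. Statements on the series, on what has been measured and on what is new or still open speak of the compounds shown alone.

Three compounds built on the shared core have numbers in an ADME assay on WI-38 cells (Homo sapiens) for inhibition, read by MTT assay, with a stated time of 72 h; a higher number here means a weaker inhibitor, a lower number a stronger inhibitor. Compound 1 `Nc1ncn(C/C=C2\OC(=O)C(OCc3ccccc3)=C2OCc2ccccc2)c(=O)n1` gives 4670 nM, compound 3 `O=C1O[C@H]([C@@H](O)Cn2ccc(NC(=O)c3ccccc3)nc2=O)C(OCc2ccccc2)=C1OCc1ccccc1` gives 8820 nM, and compound 2 `NC1(CCn2cc(F)c(=O)[nH]c2=O)OC(=O)C(OCc2ccccc2)=C1OCc1ccccc1` gives 36200 nM, the highest of the three; its step to compound 3 lies beyond the scatter, and so does its step to compound 1. Compound 4 `Cc1cn(CCC2(N)OC(=O)C(OCc3ccccc3)=C2OCc2ccccc2)c(=O)[nH]c1=O` differs from compound 2 in one place: methyl in place of fluoro on an aromatic carbon. Going by the values given here, no measured pair shows this change, so its effect in this assay is not known from the data. Given that compound 2 already gives 36200 nM, a small rise or no step beyond the scatter is expected, with a 1.4-fold higher number from compound 2 to compound 4 (0.14 log units; within the scatter) as the expected step. Compound 4 is estimated at 50000 nM, within 15000 nM to 150000 nM.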

Compound 4, half-maximal inhibitory concentration: > 100000 nM
Compound 4: only a limit was reported; the forecaster's own chance of this, stated with the estimate: 25%; middle value at least 2.0-fold (0.30 log units) from the limit.
By their numbers in this assay, from the lowest: compounds 1 and 3 (each within the scatter of the next); then compound 2. At a limit, above all of these: compound 4.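

In this assay, going by these compounds alone, the first measured pair for methyl in place of fluoro on an aromatic carbon gives an at least 2.7-fold higher number from compound 2 to compound 4 (0.44 log units; beyond the scatter), so this position on the six-membered aromatic ring with 2 nitrogen responds to the change, towards a weaker inhibitor. The reading for compound 4 is a limit, so the step has a floor but no full size: the limit of > 100000 nM in this assay, at which 1 of the 4 values shown sits.

From the compounds shown here alone, whether hydrogen, chloro, an amine or an ethyl group at this position would give a lower or higher number stays open. With a single pair, nothing shows whether the change behaves alike on other side chains of the shared core.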